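From 2-fluorophenyl to 3-chlorophenyl on the amide-type nitrogen

This account rests on a few compounds, and the source may have more. Where it says the series, first, only, none or still open, it means among the compounds named here.

In a functional assay on T47D cells (Homo sapiens) for inhibition, read by CCK-8 assay, with a stated time of 72 h, tested at 1 uM (a higher number here means more inhibition of growth at the concentration tested, a lower number less inhibition of growth), compound 2 `CN(C)C(=O)c1cc2cnc(Nc3ccc(NC(=O)C4(C(=O)Nc5ccccc5F)CC4)cc3)nc2n1C1CCCC1` gives 85.2%, the higher of two numbers, while compound 1 `CN(C)C(=O)c1cc2cnc(Nc3ccc(NC(=O)C4(C(=O)Nc5ccc(Cl)cc5)CC4)cc3)nc2n1C1CCCC1` gives 22.8%. Going by the values given here, the one measured step, a number 62.4 percentage points higher from compound 1 to compound 2 (beyond the scatter), is large and beyond the scatter; it puts 2-fluorophenyl in place of 4-chlorophenyl on an amide-type nitrogen. Compound 3 `CN(C)C(=O)c1cc2cnc(Nc3ccc(NC(=O)C4(C(=O)Nc5cccc(Cl)c5)CC4)cc3)nc2n1C1CCCC1` has 3-chlorophenyl in place of 2-fluorophenyl at that nitrogen: 3-chlorophenyl in place of 2-fluorophenyl on an amide-type nitrogen. Among the compounds with values here, no 3-chlorophenyl compound has been measured, so only that step bears on the change, and it points downward. The expected step is a number 35.2 percentage points lower from compound 2 to compound 3 (beyond the scatter), a loss beyond the scatter but smaller than the measured one. For compound 3 the estimate is 50%, with an expected range of 20% to 85%.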

Compound 3, percent growth inhibition at one concentration: 39.3%
Estimate against measurement, compound 3: 10.7 percentage points above; the range from low to high includes it.
By their numbers in this assay, from the lowest: compound 1; then compound 3; then compound 2.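

On the amide-type nitrogen, the two chlorophenyl groups are not interchangeable in this assay: the change from 4-chlorophenyl to 3-chlorophenyl gives a number 16.5 percentage points higher from compound 1 to compound 3 (beyond the scatter) as a modest gain. The 2-fluorophenyl group still stays ahead, with a number 45.9 percentage points lower from compound 2 to compound 3 (beyond the scatter) and a large loss, although that step changes both the halogen and where it sits on the ring. No measurement on hand explains either step.

Still open, going by these compounds, is how 2-chlorophenyl and 3-fluorophenyl would read, since these would separate the halogen from its placement. On these data alone, the unsubstituted phenyl group also remains open as a reference for all three.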